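This account rests on a few compounds, and the source may have more. Where it says the series, first, only, none or still open, it means among the compounds named here.

Compound 1 `O=c1ccoc2cc(OCc3cn(Cc4cccc(F)c4)nn3)ccc12`: in a functional assay on SGC-7901 cells (Homo sapiens) for cytotoxicity, read by MTT assay, with a stated time of 48 h (on this read-out lower numbers stand for stronger inhibition and higher numbers for weaker inhibition), compound 1 gives > 100000 nM, a limit of the assay rather than a number. Compound 2 `O=c1ccoc2cc(OCc3cn(Cc4ccc(Br)cc4)nn3)ccc12`: compound 2 gives > 100000 nM, again a limit. Compound 3 `CC(C)(C)c1ccc(Cn2cc(COc3ccc4c(=O)ccoc4c3)nn2)cc1`: compound 3 gives > 100000 nM, again a limit.

Compound 1 therefore stands only at the edge of what the assay can report, with no number to place it. Compound 4 `O=c1ccoc2cc(OCc3cn(Cc4ccccc4Br)nn3)ccc12` differs from it in one place: 2-bromophenyl in place of 3-fluorophenyl on a saturated chain carbon bound to an aromatic nitrogen. The measured steps that touch this part of the molecule are a step that the two limits leave unreadable from compound 1 to compound 2 and a step that the two limits leave unreadable from compound 2 to compound 3, and neither has a readable size because of the limit of > 100000 nM in this assay, at which 3 of the 3 values shown sit. No direction can be read from them. For compound 4 the estimate is 150000 nM, with a range from 50000 nM to 500000 nM. The expected step is a step that the limit leaves unreadable from compound 1 to compound 4, none beyond the scatter.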

Compound 4, half-maximal inhibitory concentration: > 100000 nM
Compound 4 was reported as a limit (the forecaster's own chance of this, stated with the estimate: 85%); the middle value does not contradict the limit.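

Compound 4 cannot be compared in size with compound 1 or compound 2, because all of these results are limits rather than numbers: the limit of > 100000 nM in this assay, at which 4 of the 4 values shown sit. The compounds shown leave open whether changing the halogen-bearing or alkyl-bearing phenyl group affects activity at all in this assay.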